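Series notes: pyrimidinyl ether analogue, lipophilicity outlook

This account rests on a few compounds, and the source may have more. Where it says the series, first, only, none or still open, it means among the compounds named here.

Compound 1, `Cc1ccnc([C@@H](C)Oc2cc3oc(=O)n(CCC(=O)O)c3cc2Cl)c1`: 2.15
Compound 2, `C[C@@H](Oc1cc2sc(=O)n(CCC(=O)O)c2cc1Cl)c1ccccn1`: 1.81
Compound 3, `C[C@@H](Oc1cc2cnn(CCC(=O)O)c2cc1Cl)c1ccccn1`: 1.7

All three measured compounds were read in a physicochemical assay for lipophilicity, read by HPLC, at pH 7.4; a higher number here means a more lipophilic compound, a lower number a more polar compound. Compound 1 gives the highest of the three numbers. The nearest to it is compound 2, whose number lies lower by a margin beyond the scatter; the furthest is compound 3, whose number lies lower by a larger margin, also beyond the scatter. Going by the values given here, the three differ from one another in more than one place, so no single step between measured compounds can be isolated, and the values show only that compound 1 sits at the top of this small set.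

Compound 4, `C[C@@H](Oc1cc2oc(=O)n(CCC(=O)O)c2cc1Cl)c1ncccn1`, has not yet been measured in this assay. Relative to compound 1 the change is pyrimidin-2-yl in place of 4-methylpyridin-2-yl on a saturated chain carbon bound to an oxygen on an aromatic ring and a saturated chain carbon. Among the compounds with values here, no measured pair in this set isolates this change, so the expectation rests on the change itself and on the position of compound 1. The expected step is a number 1.15 log units lower from compound 1 to compound 4 (beyond the scatter), a drop in this assay beyond the scatter. For compound 4 the estimate in this assay is 1, with a range from 0.5 to 1.5.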

Compound 4, distribution coefficient: 0.83
The estimate for compound 4 lay 0.17 log units above the measured number; low and high end bracket the measured number.
By their numbers in this assay, from the lowest: compound 4; then compounds 3 and 2 (each within the scatter of the next); then compound 1.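

Pyrimidin-2-yl in place of 4-methylpyridin-2-yl, on a saturated chain carbon bound to an oxygen on an aromatic ring and a saturated chain carbon, gives a number 1.32 log units lower from compound 1 to compound 4 (beyond the scatter) in this assay, the first step in the series that isolates a single place and a large one, so the group held at this position strongly moves this read-out. The step is nevertheless a compound change: the methyl of 4-methylpyridin-2-yl leaves, while the ring goes from 1 hetero atom to 2 hetero atoms and from 1 hydrogen-bond acceptor to 2 hydrogen-bond acceptors, and a single pair cannot separate these parts. Nothing available here bears on the reason for the size of this step.

From the compounds shown here alone, how much of the step belongs to the loss of the methyl and how much to the ring change remains open, as does whether the same step would hold on a different core. Also open, going by these compounds, is where a phenyl ring at this position, or a pyrimidin-2-yl carrying a methyl or an amine, would fall in this read-out.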